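The compounds below may be only part of what the source reports. "The series", "measured", "known", "first", "only" and "open" are said of these compounds alone.

In an ADME assay on BaF3 cells (Mus musculus) for inhibition, read by CellTiter-Glo, with a stated time of 72 h (a higher number here means a weaker inhibitor of growth, a lower number a stronger inhibitor of growth), compound 1 `Cc1ccc(Nc2ncc3c(n2)N(C2CC2)C(=O)N(c2cc(NC(=O)c4ccc(C)c(C(F)(F)F)c4)ccc2C)C3)cn1` gives 649 nM as its reading, and compound 2 `CCN1CCN(C(=O)c2ccc(Nc3ncc4c(n3)N(C)C(=O)N(c3cc(NC(=O)c5cccc(C(F)(F)F)c5)ccc3C)C4)cn2)CC1` gives 728 nM as its reading. Going by the values given here, these two numbers lie within the scatter of each other, so compound 1 stands level with the only other measured member of the series, and no ranking can be drawn from them. The change from compound 1 to compound 3 `Cc1ccc(Nc2ncc3c(n2)N(C2CCCCC2)C(=O)N(c2cc(NC(=O)c4ccc(C)c(C(F)(F)F)c4)ccc2C)C3)cn1` is cyclohexyl in place of cyclopropyl on an amide-type nitrogen in a ring and nothing else in the structure differs. Among the compounds with values here, no measured step covers this position, so the expectation in this assay has no direct support from the data. The working guess is a small loss of growth inhibition, meaning a somewhat higher number that may not clear the scatter. The expected change is a 1.4-fold higher number from compound 1 to compound 3 (0.14 log units; within the scatter) in this estimate, and the opposite direction cannot be excluded. For compound 3 the estimated concentration for half growth inhibition is 900 nM with an expected range from 300 nM to 2700 nM across repeat measurements.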

Compound 3, concentration for 50% growth inhibition: > 5000 nM
Compound 3: no number, only a limit (the forecaster's own chance of this, stated with the estimate: 3%); middle value at least 5.5-fold (0.74 log units) from the limit.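

Cyclohexyl in place of cyclopropyl on an amide-type nitrogen in a ring gives an at least 7.7-fold higher number from compound 1 to compound 3 (0.88 log units; beyond the scatter) in this assay, so this position, which no earlier step covered, does respond to the group placed on it. Compound 3 reads > 5000 nM, which is a limit of the assay and not a number. The step therefore fixes only the least possible loss of growth inhibition for this change, and its true size remains unknown: the limit of > 5000 nM in this assay, at which 1 of the 3 values shown sits.

As far as these compounds go, with only cyclopropyl and cyclohexyl compared in one step at this position, it stays open whether the loss sets in gradually or abruptly between them, as cyclobutyl or cyclopentyl could show, and whether an open chain such as isopropyl or a ring carrying an amine such as piperidin-4-yl would read closer to compound 1 or to compound 3. Also open, from the compounds shown here alone, is whether the same change has a similar effect when the rest of the structure differs, since the step rests on a single pair of compounds and compound 2 differs from both in more than one place.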